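Phenyl for Ethynyl on the Anilide Ring

The compounds below may be only part of what the source reports. "The series", "measured", "known", "first", "only" and "open" are said of these compounds alone.

Working notes on the series. Compound 1 `C#Cc1cccc(NC(=O)CCc2cccc3c2B(O)OC3)c1` and compound 2 `C#Cc1ccccc1NC(=O)CCc1cccc2c1B(O)OC2` are built from the same atoms joined differently; the difference between the two cores is not broken down here. In a functional assay on HCT-116 cells (Homo sapiens) for antiproliferative activity, read by MTT assay, with a stated time of 72 h (a lower number here means a stronger inhibitor, a higher number a weaker inhibitor), compound 1 gives 3600 nM, while compound 2 gives 1400 nM. Compound 3 `O=C(CCc1cccc2c1B(O)OC2)Nc1ccccc1-c1ccccc1` gives 23000 nM in this assay. Of the three measured compounds, compound 2 has the lowest number and compound 3 the highest, with compound 1 standing between them, each gap beyond the scatter.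

Among the compounds with values here, the one measured step of the type in question, from compound 2 to compound 3, is phenyl in place of ethynyl on an aromatic carbon. It produced a 16-fold higher number from compound 2 to compound 3 (1.22 log units; beyond the scatter).

Compound 4 `O=C(CCc1cccc2c1B(O)OC2)Nc1cccc(-c2ccccc2)c1` has not yet been measured. It differs from compound 1 by phenyl in place of ethynyl on an aromatic carbon. Within the data shown here, this is the same kind of change as the one from compound 2 to compound 3, not the same: there the entering phenyl sits ortho to a large group, here it sits meta to a large group. Among the measured compounds shown here, with only a single precedent, and that at a different place, the size of the step is uncertain, but its direction is taken from it.

Compound 4 is expected to be a weaker inhibitor than compound 1 in this assay, with an expected step of a 5.0-fold higher number from compound 1 to compound 4 (0.70 log units; beyond the scatter), resting on the step of a 16-fold higher number from compound 2 to compound 3 (1.22 log units; beyond the scatter). Compound 4 is therefore estimated at 18000 nM, within a range from 6000 nM to 60000 nM.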

Compound 4, half-maximal inhibitory concentration: 890 nM
Compound 4: the middle estimate sits 20-fold (1.31 log units) above what was measured; the measured number lies below the stated range.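

Phenyl in place of ethynyl on an aromatic carbon, meta to a large group, gave a 4.0-fold lower number from compound 1 to compound 4 (0.61 log units; beyond the scatter) in this assay, so the change that weakened the inhibitor on one core strengthened it on the other. The two steps run in opposite directions, and the gap between them is beyond the scatter, so the step measured on one core cannot be carried over to the other in this series, neither in size nor in direction: the same change on two cores in this assay, a 16-fold higher number (1.22 log units; beyond the scatter) from compound 2 to compound 3 and a 4.0-fold lower number (0.61 log units; beyond the scatter) from compound 1 to compound 4, 66-fold (1.82 log units) apart, beyond the scatter of two such steps

What the comparison does not show is the reason for the reversal, since there is one pair on each core and the entering phenyl stands at a different place in each, leaving the effect of that place and the effect of the rest of the structure unseparated.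

From the compounds shown here alone, it remains open whether the gain seen at this place on the core of compound 1 is particular to phenyl or extends to other groups there, such as a methyl, a pyridyl ring, or a phenyl ring carrying an amine or a carboxylic acid. Going by these compounds, it also remains open whether the reversal appears in any read-out other than this assay.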